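Toward compound 4: a hydroxymethyl triazole on the shared core

The source may report more compounds than this note shows. Statements on the series, on what has been measured and on what is new or still open speak of the compounds shown alone.

Measured compounds and their values:
Compound 1, `COc1nc2ccc(Br)cc2cc1C(c1ccccc1)n1cc(-c2ccc(Br)cc2)nn1`, 6.92%
Compound 2, `COc1nc2ccc(Br)cc2cc1C(c1ccccc1)n1cc(-c2ccccc2F)nn1`, 14.1%
Compound 3, `CCCc1cn(C(c2ccccc2)c2cc3cc(Br)ccc3nc2OC)nn1`, -2.25%

All three were tested in an ADME assay on HeLa cells (Homo sapiens) for cytotoxicity, read by sulforhodamine B assay, with a stated time of 48 h, tested at 10 uM; a higher number here means more inhibition at the concentration tested (going by the name of the read-out), a lower number less inhibition. Among the measured compounds shown here, compound 3 has the lowest of the three numbers, yet the step of a number 9.2 percentage points lower from compound 1 to compound 3 (within the scatter) lies within the scatter, and only the step of a number 16.4 percentage points lower from compound 2 to compound 3 (beyond the scatter) is beyond it; the step of a number 7.2 percentage points higher from compound 1 to compound 2 (within the scatter) is also within the scatter. On these numbers the inhibition of compound 3 cannot be set apart as lower than that of both other compounds.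

Compound 4, `COc1nc2ccc(Br)cc2cc1C(c1ccccc1)n1cc(CO)nn1`, is not yet measured. It differs from compound 3 in one place: hydroxy in place of ethyl on a saturated chain carbon bound to an aromatic carbon. Read one bond further out, this is propyl becoming hydroxymethyl on the triazole. For the measured compounds named here, none of the measured steps exchanges a chain for a hydroxy group; the steps that bear on this position all swap one carbon substituent for another, and all three compounds sit at low inhibition. With nothing in the data pointing elsewhere, compound 4 is expected to stay near compound 3, a step of a number 5.3 percentage points higher from compound 3 to compound 4 (within the scatter), not beyond the scatter. Compound 4 is therefore estimated at 3%, within a range from -10% to 16%.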

Compound 4, a percentage reported as inhibition, at one concentration (the size of the read-out at that concentration, not a potency): 0.25%
Compound 4: the middle estimate sits 2.8 percentage points above what was measured, and the stated range covers the measured number.
By their numbers in this assay, from the lowest: compounds 3, 4, 1 and 2 (each within the scatter of the next, the first and the last beyond it).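

In this assay, among the compounds shown here, this is the first exchange of a chain for a hydroxy group at this position, and it gives a number 2.5 percentage points higher from compound 3 to compound 4 (within the scatter): propyl and hydroxymethyl on the triazole cannot be told apart here, so placing a hydroxy group on the chain does not separate the two compounds. Against the two aryl groups, hydroxymethyl falls in the same way as propyl, with a number 13.9 percentage points lower from compound 2 to compound 4 (beyond the scatter) and a number 6.7 percentage points lower from compound 1 to compound 4 (within the scatter), so only the 2-fluorophenyl compound is set apart from it. No evidence is available that would explain these numbers.

As far as these compounds go, it remains open whether an amine, a carboxylic acid or a chain longer than propyl at this position would stand apart from hydroxymethyl. From the compounds shown here alone, whether a phenyl ring bearing other groups would give a number clearly above that of compound 2 also remains open.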